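From a Single Enantiomer to the Undefined Mixture

A few compounds are considered here, and "the series" means these few. Any claim that something is new, unique, unknown or untested is made for them only; others in the source may bear on it.

Of the compounds shown here, three sharing the same brominated core have been measured in a functional assay on CCRF-CEM cells (Homo sapiens) for antiproliferative activity, read by MTT assay, with a stated time of 48 h, tested at 100 uM; a lower number here means a stronger effect, a higher number a weaker effect of the compound at the concentration tested. Compound 1 `OC(CCn1nc2c(Br)c(Br)c(Br)c(Br)c2n1)c1cccc(Br)c1` gives 0%. Compound 2 `C[C@@H](O)CCn1nc2c(Br)c(Br)c(Br)c(Br)c2n1` gives 24%, and compound 3 `C[C@H](O)CCn1nc2c(Br)c(Br)c(Br)c(Br)c2n1` gives 10%. Compound 3 thus stands second highest of the three numbers; its gap to compound 1 lies within the scatter, while its gap to compound 2 lies beyond it.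

Among the compounds with values here, the one measured step that bears on the next compound is a number 14 percentage points lower from compound 2 to compound 3 (beyond the scatter), a modest change that rests on the fact that compounds 2 and 3 differ only in the configuration as drawn alone. Compound 4 `CC(O)CCn1nc2c(Br)c(Br)c(Br)c(Br)c2n1` differs from compound 3 in this way: the two compounds have the same atoms and bonds; at least one stereo element is drawn with a configuration in one of them and without one in the other: 1 of 1 stereo elements differ; a stereocentre at a saturated chain carbon is drawn S in compound 3 and without a configuration in compound 4. A compound drawn without a configuration may be taken to represent both forms, so its number would be expected to lie between those of compound 2 and compound 3. The expected step is a number 7 percentage points higher from compound 3 to compound 4 (within the scatter), which stays within the scatter of this assay. Compound 4 is therefore estimated at 17%, with a range from 5% to 30%.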

Compound 4, a percentage reported as activity, at one concentration (the size of the read-out at that concentration, not a potency): 0%
For compound 4 the middle estimate is 17 percentage points above the measured one; the whole stated range lies above it.
By their numbers in this assay, from the lowest: compounds 1, 4 and 3 (each within the scatter of the next); then compound 2.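

In this assay the form drawn without a configuration does not land midway between the two drawn forms: there is a number 10 percentage points lower from compound 3 to compound 4 (within the scatter), so it cannot be told apart from the form drawn S, yet there is a number 24 percentage points lower from compound 2 to compound 4 (beyond the scatter), so it does stand apart from the form drawn R. That separation rests on a single feature: the fact that one of compounds 2 and 4 is drawn with a defined configuration and the other without, at the place where they differ

A second result is new as well: methyl in place of 3-bromophenyl on the saturated chain carbon gives no change at the digits printed from compound 1 to compound 4 (within the scatter), so this swap shows no effect on the read-out at this concentration.

The compounds shown leave open what proportion of each form compound 4 contains. They also leave open whether an amine or a carboxylic acid in place of the hydroxyl group, or a longer chain, would alter the read-out.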